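A few compounds are considered here, and "the series" means these few. Any claim that something is new, unique, unknown or untested is made for them only; others in the source may bear on it.

Compound 1 `Nc1nc(Cl)c(-c2ccco2)c(N[C@@H]2C[C@H](CO)[C@@H](O)[C@H]2O)n1`, compound 2 `Nc1nc(Cl)c(-c2cc3ccccc3s2)c(N[C@@H]2C[C@H](CO)[C@@H](O)[C@H]2O)n1` and compound 3 `CCNc1nc(C)c(-c2nc3ccccc3s2)c(N[C@@H]2C[C@H](CO)[C@@H](O)[C@H]2O)n1` share one core and differ only at the aromatic carbon and the amine. In an ADME assay on cells (Homo sapiens) for cytotoxicity, read by polymerase chain reaction, with a stated time of 3 days (a lower number here means that less compound is tolerated, a higher number that more compound is tolerated), compound 1 gives only a limit, > 25000 nM. Compound 2 likewise gives only a limit, > 25000 nM. The step that the two limits leave unreadable from compound 1 to compound 2 therefore cannot be read. For the measured compounds named here, compound 3 gives 12000 nM, the only real number among the three. The other two values sit at the limit of > 25000 nM in this assay, at which 2 of the 3 values shown sit. Compound 4 `Cc1nc(NCCC(F)(F)F)nc(N[C@@H]2C[C@H](CO)[C@@H](O)[C@H]2O)c1-c1nc2ccccc2s1` differs from compound 3 by trifluoromethyl in place of hydrogen on a saturated chain carbon, two bonds along the chain from a nitrogen on an aromatic ring. Going by the values given here, no measured step concerns this change, so nothing here points to a move in this assay beyond the usual scatter. Compound 4 is therefore expected to give about 12000 nM, somewhere between 4000 nM and 30000 nM. The expected step is no change at the digits printed from compound 3 to compound 4 (within the scatter).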

Compound 4, half-maximal cytotoxic concentration: 9000 nM
Estimate against measurement, compound 4: 1.3-fold (0.12 log units) above; the measured number falls inside the stated range.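

In this assay, for the compounds shown here, the only readable step at this chain is a 1.3-fold lower number from compound 3 to compound 4 (0.12 log units; within the scatter). A trifluoromethyl group on a saturated chain carbon, two bonds along the chain from a nitrogen on an aromatic ring, therefore leaves the number within the scatter of that of the ethylamino compound. Compound 1 and compound 2 give only a limit, so they add no number to this comparison: the limit of > 25000 nM in this assay, at which 2 of the 4 values shown sit.

Going by these compounds, whether a longer chain, a hydroxyl group or an amine at this carbon would behave the same way remains open.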